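The compounds below may be only part of what the source reports. "The series", "measured", "known", "first", "only" and "open" are said of these compounds alone.

Measured compounds:
compound 1 `O=C1O[C@@H](CN2CCCCC2)CN1c1ccc(-n2cc(-c3ccccn3)cn2)c(F)c1`, 3.1
compound 2 `O=C1CSC(=O)N1C[C@H]1CN(c2ccc(-n3cc(-c4ccccn4)cn3)c(F)c2)C(=O)O1`, 2.18
compound 3 `CC(=O)OC[C@H]1CN(c2ccc(-n3cc(-c4ccccn4)cn3)c(F)c2)C(=O)O1`, 2.09

These three compounds share one core and differ only in the group carried on a saturated chain carbon bound to a saturated ring carbon. In a physicochemical assay for lipophilicity, read by HPLC, measured as octanol-water partition (on this read-out lower numbers stand for lower lipophilicity and higher numbers for higher lipophilicity), compound 3 holds the lowest of the three numbers, although its gap to compound 2 is within the scatter; only compound 1 stands clearly apart. The steps of a number 0.92 log units lower from compound 1 to compound 2 (beyond the scatter) and a number 1.01 log units lower from compound 1 to compound 3 (beyond the scatter) show that exchanging piperidin-1-yl for either of the two neutral groups lowers the read-out, whereas a number 0.09 log units lower from compound 2 to compound 3 (within the scatter) shows that exchanging one such neutral group for another hardly moves it.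

Compound 4 `O=C1O[C@@H](Cn2ccnn2)CN1c1ccc(-n2cc(-c3ccccn3)cn2)c(F)c1` carries the change (1H-1,2,3-triazol-1-yl in place of acetoxy on a saturated chain carbon bound to a saturated ring carbon). The step from compound 2 to compound 3 is the closest guide, since it too exchanges one neutral group for another at this position and stayed within the scatter. A small lowering of the read-out, if anything, is therefore expected for compound 4: a number 0.34 log units lower from compound 3 to compound 4 (beyond the scatter). Compound 4 is estimated at 1.75, with a range from 1.25 to 2.25.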

Compound 4, partition coefficient: 2
The estimate for compound 4 lay 0.25 log units below the measured number, within the range that was stated.
By their numbers in this assay, from the lowest: compounds 4, 3 and 2 (each within the scatter of the next); then compound 1.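

In this assay, the steps of a number 0.09 log units lower from compound 3 to compound 4 (within the scatter) and a number 0.18 log units lower from compound 2 to compound 4 (within the scatter) show that 1H-1,2,3-triazol-1-yl, a five-membered aromatic ring with 3 hetero atoms, cannot be told apart from acetoxy, which has no ring, or from 2,4-dioxo-1,3-thiazolidin-3-yl. The step of a number 1.10 log units lower from compound 1 to compound 4 (beyond the scatter) confirms that, among these four compounds, only the piperidin-1-yl of compound 1 stands apart at this position. Nothing available explains why these three different groups give such similar numbers.

As far as these compounds go, it remains open whether the higher number of compound 1 belongs to piperidin-1-yl alone or would also appear with a smaller amine such as dimethylamino. The compounds shown also leave open where a carboxylic acid or a longer chain in this place would fall on this read-out.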